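The source may report more compounds than this note shows. Statements on the series, on what has been measured and on what is new or still open speak of the compounds shown alone.

In a functional assay on cells (Cancer cell lines, Homo sapiens) for cytotoxicity, read by sulforhodamine B assay, with a stated time of 48 h (a higher number here means a weaker inhibitor of growth, a lower number a stronger inhibitor of growth), the three measured compounds stand as follows:

Compound 1, `O=C1N=C(N2N=C(c3ccccc3)CC2c2ccccc2O)S/C1=C1/C(=O)Nc2ccc(Br)cc21`: 260 nM
Compound 2, `COc1ccc(C2CC(c3ccccc3)=NN2C2=NC(=O)/C(=C3\C(=O)Nc4ccccc43)S2)cc1`: 2020 nM
Compound 3, `COc1ccc(C2CC(c3ccccc3)=NN2C2=NC(=O)/C(=C3\C(=O)Nc4ccc(Br)cc43)S2)cc1`: 200 nM

Compound 3 gives the lowest of the three numbers in this assay. Its nearest neighbour is compound 1, a step of a 1.3-fold lower number from compound 1 to compound 3 (0.11 log units; within the scatter), which is within the scatter. Compound 2 is furthest away, with a 10-fold lower number from compound 2 to compound 3 (1.00 log units; beyond the scatter), a modest step beyond the scatter.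

Compound 4, `CN(C)c1ccc(C2CC(c3ccccc3)=NN2C2=NC(=O)/C(=C3\C(=O)Nc4ccc(Br)cc43)S2)cc1`, has not yet been measured. It differs from compound 3 in one place: dimethylamino in place of methoxy on an aromatic carbon

Among the compounds with values here, of the measured steps, only the one from compound 1 to compound 3 bears on this change, since it also alters the aryl group on the saturated ring carbon while leaving the bromo in place; that step was a 1.3-fold lower number from compound 1 to compound 3 (0.11 log units; within the scatter), within the scatter. The step from compound 2 to compound 3 concerns the bromo, which compound 4 keeps, so it does not speak to the present change. With just one comparable step and that one flat, no movement beyond the scatter is expected in this assay from compound 3 to compound 4, in either direction, and the expected step is a 1.2-fold higher number from compound 3 to compound 4 (0.06 log units; within the scatter). Compound 4 is therefore estimated at 230 nM, with a range from 80 nM to 650 nM.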

Compound 4, concentration for 50% growth inhibition: 220 nM
Compound 4: the middle estimate sits 1.0-fold (0.02 log units) above what was measured; measured number inside the range.
By their numbers in this assay, from the lowest: compounds 3, 4 and 1 (each within the scatter of the next); then compound 2.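

Putting dimethylamino in place of methoxy, on an aromatic carbon para to a large group, gives a 1.1-fold higher number from compound 3 to compound 4 (0.04 log units; within the scatter) in this assay, a direct reading of this one substituent with the rest of compound 3 held fixed. The comparison with the 2-hydroxyphenyl group gives a 1.2-fold lower number from compound 1 to compound 4 (0.07 log units; within the scatter), so compounds 1, 3 and 4, which all carry the bromo, now lie within the scatter of one another across three different aryl groups on the saturated ring carbon. No measurement shown accounts for this flat result.

All three aryl groups carry a substituent with oxygen or nitrogen, so the compounds shown leave open whether a plain phenyl, a chloro group or a carboxylic acid at this place would give a number in the same range. Dimethylamino is also seen only with the bromo in place, so it remains open whether the bromo effect seen in a 10-fold lower number from compound 2 to compound 3 (1.00 log units; beyond the scatter) would carry over to the 4-(dimethylamino)phenyl series.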